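Changing the Aryl Group on the Ring Nitrogen

The compounds below may be only part of what the source reports. "The series", "measured", "known", "first", "only" and "open" are said of these compounds alone.

Compound 1, `COc1ccccc1N1C(=O)/C(=C/c2ccc(OCc3ccc(C(=O)O)cc3)cc2)SC1=S`: 2000 nM
Compound 2, `COc1ccccc1N1C(=O)/C(=C/c2ccc(OCC(=O)Nc3ccc(C(=O)O)cc3)cc2)SC1=S`: 10000 nM
Compound 3, `O=C(O)c1ccc(COc2cccc(/C=C3\SC(=S)N(c4ccc([N+](=O)[O-])cc4)C3=O)c2)cc1`: a limit, > 10000 nM

In an assay on isolated protein for inhibition of Apoptosis regulator Bcl-2 (Homo sapiens), read by fluorescence polarization (a lower number here means a stronger inhibitor, a higher number a weaker inhibitor), compound 1 gives 2000 nM, the lowest of the two numbers shown. For the measured compounds named here, compound 2 gives 10000 nM in this assay, and the only measured step between single-change neighbours is a 5.0-fold higher number from compound 1 to compound 2 (0.70 log units; beyond the scatter). Compound 3 returns only a limit, > 10000 nM, so no number is known for it (the limit of > 10000 nM in this assay, at which 1 of the 3 values shown sits).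

Compound 4, `O=C(O)c1ccc(COc2ccc(/C=C3\SC(=S)N(c4ccc(I)cc4)C3=O)cc2)cc1`, differs from compound 1 in one place: 4-iodophenyl in place of 2-methoxyphenyl on an amide-type nitrogen in a ring. Going by the values given here, no measured step touches this part of the molecule; the step from compound 1 to compound 2 alters the chain on the other side of the shared core, so it offers no direct guide. Compound 3 also carries a different group on that same nitrogen, together with a second difference, and gives only a limit. With the one indirect hint pointing toward weaker binding, compound 4 is expected to give a somewhat higher number, estimated at 5000 nM with a likely range from 1500 nM to 15000 nM. That estimate means a step of a 2.5-fold higher number from compound 1 to compound 4 (0.40 log units; beyond the scatter), expected to fall beyond the usual scatter.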

Compound 4, inhibition constant: 4300 nM
Beside the measured number, compound 4's estimate is 1.2-fold (0.07 log units) above it, within the range that was stated.
By their numbers in this assay, from the lowest: compound 1; then compound 4; then compound 2.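

For the compounds shown here, this is the first measured change on the amide-type nitrogen in the ring, and in this assay it gives a 2.2-fold higher number from compound 1 to compound 4 (0.33 log units; beyond the scatter). Putting 4-iodophenyl in place of 2-methoxyphenyl therefore makes the compound a modestly weaker inhibitor, but it still gives a measured number, so this position accepts at least one quite different aryl group without a complete loss of binding. Compound 3 carries another group on that nitrogen and also differs elsewhere, and it gives only a limit, so no step to it can be read: the limit of > 10000 nM in this assay, at which 1 of the 4 values shown sits.

The swap changes two things at once, since the methoxy group, with its one hydrogen-bond acceptor, gives way to iodine, and the substituent also sits at a different numbered place on the aromatic ring, so the data do not show which of these produces the step. A plain phenyl, a 4-methoxyphenyl or a 2-iodophenyl on the same nitrogen would separate the identity of the group from its place on the ring, and this remains open in the compounds shown.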